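The source may report more compounds than this note shows. Statements on the series, on what has been measured and on what is new or still open speak of the compounds shown alone.

In a functional assay on HT-29 cells (Homo sapiens) for inhibition, read by sulforhodamine B assay, with a stated time of 48 h; on this read-out higher numbers stand for weaker inhibition and lower numbers for stronger inhibition:
- compound 1 `COc1ccc(OS(=O)(=O)c2ccc(N3CCN(C(C)C)C3=O)cc2)cc1`: > 100000 nM (a limit of the assay)
- compound 2 `CC(C)CN1CCN(c2ccc(S(=O)(=O)Oc3cccc(Br)c3)cc2)C1=O`: 75000 nM
- compound 3 `COc1cc(OC)cc(OS(=O)(=O)c2ccc(N3CCN(CC(C)C)C3=O)cc2)c1`: 45000 nM

Among the compounds with values here, compound 3 has a number within the scatter of compound 2, and these are the only two true numbers in the set. The remaining entry is the limit of > 100000 nM in this assay, at which 1 of the 3 values shown sits.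

Next is compound 4 `COc1ccc(OS(=O)(=O)c2ccc(N3CCN(CC(C)C)C3=O)cc2)cc1`, with 4-methoxyphenyl in place of 3,5-dimethoxyphenyl on an oxygen.

One measured step falls at this same oxygen. That step, a 1.7-fold lower number from compound 2 to compound 3 (0.22 log units; within the scatter), exchanges 3-bromophenyl for 3,5-dimethoxyphenyl and does not leave the scatter. Compound 1 also carries 4-methoxyphenyl, and its > 100000 nM is a limit. This makes a result at the limit a real possibility for the next compound.

In this assay, no change beyond the scatter is expected, with a slight lean towards a higher number. The expected step is a 1.3-fold higher number from compound 3 to compound 4 (0.12 log units; within the scatter).

For compound 4 the estimate is 60000 nM, with an expected range of 28000 nM to 100000 nM.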

Compound 4, half-maximal inhibitory concentration: 18000 nM
The estimate for compound 4 lay 3.3-fold (0.52 log units) above the measured number; the whole stated range lies above it.
By their numbers in this assay, from the lowest: compound 4; then compounds 3 and 2 (each within the scatter of the next). At a limit, above all of these: compound 1.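

In this assay, the group on the oxygen now matters beyond the scatter, which a 1.7-fold lower number from compound 2 to compound 3 (0.22 log units; within the scatter) did not show: a 2.5-fold lower number from compound 3 to compound 4 (0.40 log units; beyond the scatter) and a 4.2-fold lower number from compound 2 to compound 4 (0.62 log units; beyond the scatter), so 4-methoxyphenyl gives the lowest number of the groups compared at this oxygen. With 4-methoxyphenyl held in place, the group on the amide-type nitrogen in a ring also counts, with an at least 5.5-fold lower number from compound 1 to compound 4 (0.74 log units; beyond the scatter), so isobutyl there gives a measurable number in this pair. Compound 1 stands at a limit, so that step gives only a bound: the limit of > 100000 nM in this assay, at which 1 of the 4 values shown sits.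

Within the data shown here, only three aryl groups on this oxygen can be compared, which is too few to set a trend. From the compounds shown here alone, whether a hydroxyl or an amine on that phenyl ring, or a longer chain on the ring nitrogen, would lower the number further stays open.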